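The source may report more compounds than this note shows. Statements on the series, on what has been measured and on what is new or still open speak of the compounds shown alone.

Compound 2 `COc1ccc(/C=N/NC(=S)NC(C)(C)[C@H]2CC=C(C)CC2)cc1` gives 1500 nM in a functional assay on K562 cells (Homo sapiens) for inhibition, read by sulforhodamine B assay, with a stated time of 48 h (on this read-out higher numbers stand for weaker inhibition of growth and lower numbers for stronger inhibition of growth), the lowest of the two numbers shown, while compound 1 `CC1=CC[C@H](C(C)(C)N=C=S)CC1` gives 4000 nM in this assay, a gap beyond the scatter. Compound 3 `CC1=CC[C@H](C(C)(C)NC(=S)N/N=C/c2ccco2)CC1` differs from compound 2 by furan-2-yl in place of 4-methoxyphenyl on a carbon with a double bond to nitrogen. For the measured compounds named here, no pair of measured compounds shows this change, so its size is unknown from the data. The expected step is a 1.5-fold higher number from compound 2 to compound 3 (0.17 log units; within the scatter), a small loss that may well stay within the scatter. Compound 3 is estimated at 2200 nM in this assay, with a range from 700 nM to 7000 nM.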

Compound 3, concentration for 50% growth inhibition: 100 nM
Estimate against measurement, compound 3: 22-fold (1.34 log units) above, outside the stated range (below it).
By their numbers in this assay, from the lowest: compound 3; then compound 2; then compound 1.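

For the compounds shown here, the place on the carbon with a double bond to nitrogen, untested by the earlier compounds, turns out to matter strongly in this assay: furan-2-yl in place of 4-methoxyphenyl gives a 15-fold lower number from compound 2 to compound 3 (1.18 log units; beyond the scatter), a large step well beyond the scatter. The substituent here is therefore not a silent part of the structure on this read-out. Nothing in the data at hand accounts for the size of this step. Going by these compounds, whether thiophen-2-yl or plain phenyl at this place would match furan-2-yl stays open, as does whether the step depends on the five-membered ring or on the methoxy group.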